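The compounds below may be only part of what the source reports. "The series", "measured", "known", "first", "only" and "open" are said of these compounds alone.

Measured so far:
compound 1 `O=C(O)c1cccc(CNc2cc(C(F)(F)F)cc3[nH]ncc23)c1`, in an assay for inhibition of Tryptophan 2,3-dioxygenase (Homo sapiens), with stated times of 10 min and 60 min (on this read-out higher numbers stand for weaker inhibition and lower numbers for stronger inhibition), compound 1 gives 1690 nM
compound 2 `O=[N+]([O-])c1ccc(O)cc1CNc1cc(Br)cc2[nH]ncc12`, in this assay compound 2 gives 460 nM

Of the two numbers, compound 1 carries the higher one; compound 2 stands lower, and the gap between the two lies beyond the usual scatter of this assay. The two compounds differ in several places at once, so their values only show where each stands and do not tell which part of the structure accounts for the gap.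

The step under consideration leads from compound 1 to compound 3 `Nc1cccc(CNc2cc(C(F)(F)F)cc3[nH]ncc23)c1`. Going by the values given here, the single change is amino in place of carboxy on an aromatic carbon. Among the compounds with values here, no measured pair in this set isolates such a change, so there is no direct basis for the size or direction of the step. The account therefore expects a step from compound 1 to compound 3 of a 1.3-fold lower number from compound 1 to compound 3 (0.11 log units; within the scatter), which is to say no change clearly beyond the scatter. On that basis compound 3 is estimated at 1300 nM in this assay, within a range from 400 nM to 4500 nM.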

Compound 3, half-maximal inhibitory concentration: 2510 nM
Compound 3: middle estimate off by 1.9-fold (0.29 log units), on the low side; low and high end bracket the measured number.
By their numbers in this assay, from the lowest: compound 2; then compounds 1 and 3 (each within the scatter of the next).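

In this assay, going by these compounds alone, the exchange of carboxy for amino on this aromatic carbon gives a 1.5-fold higher number from compound 1 to compound 3 (0.17 log units; within the scatter), and this is the first comparison here in which only one place differs. At this place, on a six-membered aromatic ring of carbon only and meta to a large group, carboxy with its 3 heavy atoms and amino with its 1 heavy atom leave the two compounds unseparated by this read-out, even though carboxy brings a double bond that amino lacks and the two groups have the same counts of hydrogen-bond donors and acceptors. Nothing available accounts for this lack of separation.

The compounds shown leave open whether a carboxamide, a nitrile or an aminomethyl group on the same carbon would stand apart from carboxy and amino, or would likewise stay unseparated from them. They also leave open whether the same exchange would read alike with bromo in place of trifluoromethyl on the shared core, since compound 2 differs from compound 1 and compound 3 in several places at once and so cannot answer this.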